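Replacing the 4-methoxyphenyl of compound 1 with sec-butoxy

A few compounds are considered here, and "the series" means these few. Any claim that something is new, unique, unknown or untested is made for them only; others in the source may bear on it.

In a functional assay on MCF7 cells (Homo sapiens) for antiproliferative activity (on this read-out lower numbers stand for stronger inhibition and higher numbers for weaker inhibition), compound 1 (`COc1ccc(C(=O)Nc2ccc(O)c3c(=O)cc(-c4ccccc4Cl)oc23)cc1`) gives 3500 nM. Compound 3 (`CC(C)C[C@@H](NC(=O)OC(C)(C)C)C(=O)Nc1ccc(O)c2c(=O)cc(-c3ccccc3Cl)oc12`) gives 2500 nM, within the scatter of compound 1, so these two share the low end of the three numbers. Compound 2 (`COc1ccc(C(=O)Nc2c(O)cc(O)c3c(=O)cc(-c4ccccc4Cl)oc23)cc1`) gives 13000 nM.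

Compound 4 (`CCC(C)OC(=O)Nc1ccc(O)c2c(=O)cc(-c3ccccc3Cl)oc12`) carries sec-butoxy in place of 4-methoxyphenyl on a carbonyl carbon whose other neighbour is an amide-type nitrogen: sec-butoxy in place of 4-methoxyphenyl on a carbonyl carbon.

For the measured compounds named here, the only measured step, a 3.7-fold higher number from compound 1 to compound 2 (0.57 log units; beyond the scatter), is modest, but it places hydroxy in place of hydrogen on an aromatic carbon, so it says little about this change. Compound 3 is closer evidence: it also lacks the 4-methoxyphenyl, and its 2500 nM lies within the scatter of compound 1. Going by the values given here, no measured pair isolates sec-butoxy itself. A step beyond the scatter is therefore not expected, and the expected step is a 1.1-fold higher number from compound 1 to compound 4 (0.06 log units; within the scatter). For compound 4 the estimated value is 4000 nM, with an expected range of 1500 nM to 11000 nM.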

Compound 4, half-maximal inhibitory concentration: 30000 nM
The estimate for compound 4 lay 7.5-fold (0.88 log units) below the measured number, and the stated range ends below it.
By their numbers in this assay, from the lowest: compounds 3 and 1 (each within the scatter of the next); then compound 2; then compound 4.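

This position is not indifferent to the group on the carbonyl carbon: in this assay, sec-butoxy in place of 4-methoxyphenyl gives an 8.6-fold higher number from compound 1 to compound 4 (0.93 log units; beyond the scatter). Losing the 4-methoxyphenyl does not by itself set the number, since compound 3 also lacks it and gives 2500 nM, whereas compound 4 gives 30000 nM; what enters at this carbonyl carbon therefore matters. Nothing available explains the size of this step.

The compounds shown leave open whether the ring of the 4-methoxyphenyl, the oxygen of sec-butoxy joined directly to the carbonyl, or the branching of its chain goes with the higher number. A phenoxy group, a tert-butoxy group or an unbranched butyl chain on the same carbonyl carbon would help to separate these readings.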